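Swapping one small aromatic ring for another

The source may hold more compounds than are shown below. What is called first, only, known or untested is meant among the compounds shown, and "the series" means these compounds.

In a functional assay on CHO cells for agonist activity at Alpha-1A adrenergic receptor (Homo sapiens), read by FLIPR and calcium flux (a higher number here means a larger maximal response, a lower number a smaller maximal response), compound 1 `c1ccc2c(c1)CCC2c1ncc[nH]1` gives 54%, compound 2 `CS(=O)(=O)Nc1cccc2c1CCC2c1ncc[nH]1` gives 87% and compound 3 `Cc1oncc1-c1cccc2c1CCC2c1ncc[nH]1` gives 63%. Compound 3 thus stands second highest of the three: the change a number 9 percentage points higher from compound 1 to compound 3 (within the scatter) stays within the scatter, whereas the change a number 24 percentage points lower from compound 2 to compound 3 (beyond the scatter) lies beyond it. Compound 4 `c1cc(-c2nccs2)c2c(c1)C(c1ncc[nH]1)CC2` differs from compound 3 by 1,3-thiazol-2-yl in place of 5-methyl-1,2-oxazol-4-yl on an aromatic carbon. Within the data shown here, the only measured step that bears on this is the one that placed a small aromatic ring on that carbon, a number 9 percentage points higher from compound 1 to compound 3 (within the scatter), which stayed within the scatter; no measured step compares two such rings with each other. For compound 4 a step of no change at the digits printed from compound 3 to compound 4 (within the scatter) is therefore expected, within the scatter. Compound 4 is estimated at 63%, with a range from 48% to 78%.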

Compound 4, largest response reached (Emax), in percent of the reference or control that the assay uses: 64%
Beside the measured number, compound 4's estimate is 1 percentage points below it; the range from low to high includes it.
By their numbers in this assay, from the lowest: compounds 1, 3 and 4 (each within the scatter of the next); then compound 2.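

Among these compounds, exchanging one five-membered aromatic ring for another on this aromatic carbon, in this assay, gives a number 1 percentage points higher from compound 3 to compound 4 (within the scatter) and so, unlike the earlier compounds, compares two such rings directly. The 1,3-thiazol-2-yl ring gives a number 10 percentage points higher from compound 1 to compound 4 (within the scatter) as well as a number 23 percentage points lower from compound 2 to compound 4 (beyond the scatter), so among these compounds only methanesulfonamido stands apart from hydrogen beyond the scatter. No evidence is available on why these two rings behave alike.

As far as these compounds go, whether an amine, a carboxylic acid or a phenyl ring on this carbon would match compound 2 remains open.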